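The source may report more compounds than this note shows. Statements on the series, on what has been measured and on what is new or still open speak of the compounds shown alone.

Measured compounds in a functional assay on MDA-MB-231 cells (Homo sapiens) for antiproliferative activity, read by CCK-8 assay, with a stated time of 72 h; on this read-out higher numbers stand for weaker inhibition and lower numbers for stronger inhibition:
- compound 1, `Cc1ccc(C(=O)Nc2cccc(-c3oc4cc(-c5ccc(F)cc5)ccc4c(=O)c3O)c2)cc1`, gives 4350 nM
- compound 2, `COc1cc(OC)cc(C(=O)Nc2cccc(-c3oc4cc(-c5ccc(F)cc5)ccc4c(=O)c3O)c2)c1`, gives 4040 nM

Compound 2 and compound 1 sit together on these numbers: the step of a 1.1-fold lower number from compound 1 to compound 2 (0.03 log units; within the scatter) lies within the scatter, so the two are not separated by this assay. That step is also the only one that touches the aryl group on the carbonyl carbon of the amide, and it shows that exchanging one substituted phenyl ring for another at that place left the read-out essentially unchanged.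

Compound 3, `O=C(Nc1cccc(-c2oc3cc(-c4ccc(F)cc4)ccc3c(=O)c2O)c1)c1ccc(Cl)nc1`, carries the change (6-chloropyridin-3-yl in place of 3,5-dimethoxyphenyl on a carbonyl carbon). Within the data shown here, the one measured step at this position, a 1.1-fold lower number from compound 1 to compound 2 (0.03 log units; within the scatter), was flat, and no other pair in the set informs on a pyridine ring or a chlorine in this position. On that basis no step beyond the scatter is expected in this assay, in either direction, and compound 3 is estimated at 4200 nM (range 1800 nM to 9500 nM), the expected step being a 1.0-fold higher number from compound 2 to compound 3 (0.02 log units; within the scatter). The range is kept wide on the upper and lower side because only compound 1 and compound 2 inform it.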

Compound 3, half-maximal inhibitory concentration: 1760 nM
Compound 3: middle estimate off by 2.4-fold (0.38 log units), on the high side; the whole stated range lies above it.
By their numbers in this assay, from the lowest: compound 3; then compounds 2 and 1 (each within the scatter of the next).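

In this assay, the position on the carbonyl carbon is no longer flat: the 6-chloropyridin-3-yl group gives a 2.3-fold lower number from compound 2 to compound 3 (0.36 log units; beyond the scatter) and a 2.5-fold lower number from compound 1 to compound 3 (0.39 log units; beyond the scatter), whereas exchanging one substituted phenyl ring for another gave only a 1.1-fold lower number from compound 1 to compound 2 (0.03 log units; within the scatter). The aryl group on this carbonyl carbon, whose other neighbour is the amide-type nitrogen, can therefore move the read-out, although both new steps are modest and run in the same direction. Nothing in the available data bears on the reason for this shift.

The change replaces a six-membered aromatic ring of carbon only with one holding a hetero atom, and it also brings in chlorine and removes both methoxy groups, so the compounds shown cannot assign the steps to any one of these features. As far as these compounds go, whether a pyridin-3-yl group without the chlorine or a chlorophenyl group would give a similar number remains open, as does the effect of an amine or a carboxylic acid on this ring.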